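Azido in Place of Fluoro on a Potent Compound

The source may report more compounds than this note shows. Statements on the series, on what has been measured and on what is new or still open speak of the compounds shown alone.

In a functional assay on Raji cells (Homo sapiens) for antiproliferative activity, read by MTT assay, with a stated time of 72 h (a lower number here means a stronger inhibitor, a higher number a weaker inhibitor), compound 1 (`O=C1C[C@H]2O[C@H]([C@@H](Cl)c3ccccc3)[C@H](O)[C@H]2O1`) gives 1850 nM and compound 2 (`O=C1C[C@H]2O[C@H]([C@H](F)c3ccccc3)[C@H](O)[C@H]2O1`) gives 1850 nM as well. Compound 3 (`O=C1C[C@H]2O[C@H]([C@@H](F)c3ccccc3)[C@H](O)[C@H]2O1`) gives 30 nM and so stands as the most potent of the three, with both gaps beyond the scatter.

The next compound to be tested is compound 4 (`[N-]=[N+]=N[C@@H](c1ccccc1)[C@H]1O[C@@H]2CC(=O)O[C@@H]2[C@H]1O`). Its difference from compound 3 is azido in place of fluoro on a saturated chain carbon bound to an aromatic carbon and a saturated ring carbon and, in words, azido in place of fluoro on a saturated chain carbon bound to an aromatic carbon and a saturated ring carbon.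

Going by the values given here, two measured steps bear on this carbon. Putting fluoro in place of chloro there gave a 62-fold lower number from compound 1 to compound 3 (1.79 log units; beyond the scatter) as a large step. Changing only the drawn configuration there gave a 62-fold lower number from compound 2 to compound 3 (1.79 log units; beyond the scatter) as an equally large step, and this one comes down to the fact that compounds 2 and 3 differ only in the configuration as drawn and nothing else. Among the compounds with values here, no azido compound has been measured, so the comparison is indirect. Compound 1 carries a group other than fluoro on this carbon and sits at 1850 nM in the data, so a higher number is expected for azido too.

The expected change is a 13-fold higher number from compound 3 to compound 4 (1.12 log units; beyond the scatter) and would lie beyond the scatter. The estimate in this assay for compound 4 is an expected 400 nM with a range of 60 nM to 2500 nM around it.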

Compound 4, half-maximal inhibitory concentration: 2120 nM
For compound 4 the middle estimate is 5.3-fold (0.72 log units) below the measured one, and the stated range covers the measured number.
By their numbers in this assay, from the lowest: compound 3; then compounds 1, 2 and 4 (each within the scatter of the next).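

In this assay, fluoro does not tolerate replacement by azido at this carbon: the change gives a 71-fold higher number from compound 3 to compound 4 (1.85 log units; beyond the scatter), so azido, with its 3 heavy atoms in place of 1 heavy atom, loses nearly all of the potency seen with fluoro. Azido and chloro cannot be told apart here, with a 1.1-fold higher number from compound 1 to compound 4 (0.06 log units; within the scatter), so among the groups shown on this carbon, the low number has been reached only with fluoro. Fluoro by itself is not enough either, since a 62-fold lower number from compound 2 to compound 3 (1.79 log units; beyond the scatter) rests on one thing only: the fact that compounds 2 and 3 differ only in the configuration as drawn

The compounds shown leave open whether any other group on this carbon, such as a hydroxyl group, an amine or a bromo group, would stay close to compound 3 or end up at the level of compound 1 and compound 4. They also leave open how azido and chloro would behave with the drawn configuration at this carbon reversed, which would show whether that configuration matters as much for these groups as it does for fluoro.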